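Cytotoxicity notes: hexyloxy in place of propylamino

The source may hold more compounds than are shown below. What is called first, only, known or untested is meant among the compounds shown, and "the series" means these compounds.

Compound 1 `CC(C)CSc1nc(N)nc2c1ncn2/C=C1/CC1(CO)CO` is the isobutylsulfanyl member of the series; in an ADME assay on CCRF-HSB-2 cells (Homo sapiens) for cytotoxicity, with a stated time of 7 days (a lower number here means that less compound is tolerated, a higher number that more compound is tolerated), compound 1 gives 60000 nM. Compound 2 `CCCNc1nc(N)nc2c1ncn2/C=C1/CC1(CO)CO` carries propylamino in its place. In this assay compound 2 reaches only a limit of the assay, > 20000 nM, so its standing is known as a range and not as a number (the limit of > 20000 nM in this assay, at which 1 of the 2 values shown sits). The step that the limit leaves unreadable from compound 1 to compound 2 accordingly has no readable size or direction.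

Compound 3 `CCCCCCOc1nc(N)nc2c1ncn2/C=C1/CC1(CO)CO` is the next member to be measured: hexyloxy in place of propylamino on an aromatic carbon. Within the data shown here, the single measured step, a step that the limit leaves unreadable from compound 1 to compound 2, touches the same aromatic carbon, yet the limit hides its size, so it cannot set a scale for the new change. What the two measured compounds share is that both sit at high concentrations in this assay, and the expectation for compound 3 rests on that alone. Compound 3 is expected in this assay near 40000 nM, with a range from 10000 nM to 150000 nM. The step that the limit leaves unreadable from compound 2 to compound 3 is thus expected to stay within the usual scatter, with a fair chance that compound 3 again returns only a limit.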

Compound 3, half-maximal cytotoxic concentration: > 20000 nM
Compound 3 was reported as a limit; the forecaster's own chance of this, stated with the estimate: 40%; the middle value lies beyond the limit too.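

In this assay compound 3 gives > 20000 nM, which is a limit of the assay. The steps from compound 3 to compound 1 and to compound 2 cannot be read, because the values stop at a limit: the limit of > 20000 nM in this assay, at which 2 of the 3 values shown sit. The compounds shown leave open whether hexyloxy, propylamino and isobutylsulfanyl on this aromatic carbon differ at all in cytotoxicity.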